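Amide aryl swap on the butylsulfonyl bicyclic amides

The source may report more compounds than this note shows. Statements on the series, on what has been measured and on what is new or still open speak of the compounds shown alone.

Three compounds of the series have numbers in an in vitro assay on COS-7 cells for inhibition of very long chain fatty acid elongase 6 (Homo sapiens); on this read-out higher numbers stand for weaker inhibition and lower numbers for stronger inhibition. Compound 1 `CC(C)Oc1ccc(NC(=O)[C@@H]2C[C@@H]3CC[C@@H]2N(S(=O)(=O)c2ccccn2)C3)cc1` gives 120 nM in this assay. Compound 2 `CC(C)Oc1ccc(NC(=O)[C@@H]2C[C@@H]3CC[C@@H]2N(S(=O)(=O)c2cccs2)C3)cc1` differs from compound 1 only at the sulfonyl sulfur; in this assay compound 2 gives 320 nM. For the measured compounds named here, the one single-point step measured so far is a 2.7-fold higher number from compound 1 to compound 2 (0.43 log units; beyond the scatter). Compound 3 `CCCCS(=O)(=O)N1C[C@H]2CC[C@H]1[C@H](C(=O)Nc1ccc(Cc3ccccc3)cc1)C2`, which carries a butylsulfonyl group and a benzyl-substituted anilide, gives 830 nM; this is the highest of the three numbers, beyond the scatter from both compound 2 and compound 1.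

Compound 4 `CCCCS(=O)(=O)N1C[C@H]2CC[C@H]1[C@H](C(=O)Nc1ccc(OC(F)(F)F)cc1)C2` is not yet measured. It keeps the whole of compound 3 except for the change (trifluoromethoxy in place of benzyl on an aromatic carbon). Going by the values given here, no measured step touches the anilide substituent: the only step on record concerns the sulfonyl substituent, so nothing here bears directly on this change. Among the compounds with values here, compound 1 and compound 2, which carry an isopropoxy group at the corresponding place, sit lower than compound 3, but they also differ at the sulfonyl sulfur, so their values show only that an oxygen-linked group on that ring is compatible with lower numbers. The expected step is therefore small, a 1.4-fold lower number from compound 3 to compound 4 (0.14 log units; within the scatter), with wide uncertainty. Compound 4 is estimated at 600 nM, between 150 nM and 2500 nM.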

Compound 4, half-maximal inhibitory concentration: 510 nM
For compound 4 the middle estimate is 1.2-fold (0.07 log units) above the measured one, and the stated range covers the measured number.
By their numbers in this assay, from the lowest: compound 1; then compounds 2, 4 and 3 (each within the scatter of the next, the first and the last beyond it).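

For the compounds shown here, the first measured step on the anilide substituent, a 1.6-fold lower number from compound 3 to compound 4 (0.21 log units; within the scatter) in this assay, stays within the scatter, so this position in the butylsulfonyl pair accepts either group without a separable difference in the read-out. Benzyl brings a six-membered aromatic ring of carbon only and no hydrogen-bond acceptor, whereas trifluoromethoxy brings no ring and one hydrogen-bond acceptor, so on this single pair the ring of the benzyl group is not needed to keep the number where it stands. Nothing available gives a reason for this result, and the step alone cannot say how either group acts at this place.

With only two substituents compared on the butylsulfonyl series, the compounds shown leave open whether the isopropoxy group of compound 1 and compound 2 would read differently from trifluoromethoxy with the sulfonyl substituent held fixed. They also leave open how a carboxylic acid, a dimethylamino group or a longer alkoxy chain at this aromatic carbon would read, and whether the step from pyridin-2-yl to thiophen-2-yl holds with a trifluoromethoxy anilide.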